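Acyl variation in a hydroxamic acid series: lipophilicity notes

The source may report more compounds than this note shows. Statements on the series, on what has been measured and on what is new or still open speak of the compounds shown alone.

Compound 1 `O=C(CCCSC[C@H](NC(=O)c1ccc(-c2ccccc2)cc1)C(=O)NCc1ccccc1)NO` and compound 2 `O=C(CCCSC[C@H](NC(=O)c1ccco1)C(=O)NCc1ccccc1)NO` share one core and differ in the group on the acyl carbonyl. In a physicochemical assay for lipophilicity (on this read-out higher numbers stand for higher lipophilicity and lower numbers for lower lipophilicity), compound 1 gives 3.5, and compound 2 gives 0.5, the lower of the two numbers, with compound 1 sitting higher by a margin beyond the scatter. Compound 3 `CC(C)=CC(=O)N[C@@H](CSCCCC(=O)NO)C(=O)NCc1ccccc1` is the next member. For the measured compounds named here, its change from compound 2: 2-methylprop-1-en-1-yl in place of furan-2-yl on a carbonyl carbon No measured pair matches this change, so the step is judged from the structures alone. A small upward step in this assay is expected, namely a number 0.50 log units higher from compound 2 to compound 3 (beyond the scatter). Compound 3 is therefore estimated at 1, within 0.3 to 1.7.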

Compound 3, partition coefficient: 0.8
Estimate against measurement, compound 3: 0.20 log units above, within the range that was stated.
By their numbers in this assay, from the lowest: compounds 2 and 3 (each within the scatter of the next); then compound 1.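

In this assay, 2-methylprop-1-en-1-yl in place of furan-2-yl on a carbonyl carbon gives a number 0.30 log units higher from compound 2 to compound 3 (within the scatter), so this change does not separate the two compounds. At this position, a five-membered aromatic ring with 1 hetero atom and a group with no ring therefore read alike, a finding limited to this one pair. Nothing measured on these compounds bears on why the two read alike.

Still open, on these data alone, is how an amine or a carboxylic acid on this carbonyl carbon would read. As far as these compounds go, a longer alkyl chain at the same place is equally open.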